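Swapping isopropyl for methoxy on the shared core

The compounds below may be only part of what the source reports. "The series", "measured", "known", "first", "only" and "open" are said of these compounds alone.

Compound 1 `N=C(N)c1ccc(COc2ccccc2)cc1`: 167000000 nM
Compound 2 `N=C(N)c1ccc(COc2ccc([N+](=O)[O-])cc2)cc1`: 79200000 nM
Compound 3 `CC(C)c1ccc(OCc2ccc(C(=N)N)cc2)cc1`: 5360000 nM

In an ADME assay on L6 cells (Rattus norvegicus) for cytotoxicity, read by resazurin assay, with a stated time of 72 h (on this read-out lower numbers stand for stronger inhibition and higher numbers for weaker inhibition), compound 3 gives the lowest of the three numbers, 5360000 nM. Compound 4 `COc1ccc(OCc2ccc(C(=N)N)cc2)cc1` has methoxy in place of isopropyl on an aromatic carbon, para to a large group (methoxy in place of isopropyl on an aromatic carbon). Among the compounds with values here, no measured compound carries methoxy, so the nearest evidence is indirect. Isopropyl in place of hydrogen gave a large step, a 31-fold lower number from compound 1 to compound 3 (1.49 log units; beyond the scatter). Nitro in place of hydrogen gave only a modest one, a 2.1-fold lower number from compound 1 to compound 2 (0.32 log units; beyond the scatter), and isopropyl in place of nitro gave a 15-fold lower number from compound 2 to compound 3 (1.17 log units; beyond the scatter). Removing isopropyl is therefore expected to reverse much of its gain, and the expected large upward step is an 11-fold higher number from compound 3 to compound 4 (1.05 log units; beyond the scatter). Compound 4 is estimated at 60000000 nM, with an expected range of 15000000 nM to 170000000 nM.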

Compound 4, half-maximal inhibitory concentration: 143000000 nM
For compound 4 the middle estimate is 2.4-fold (0.38 log units) below the measured one; the measured number falls inside the stated range.
By their numbers in this assay, from the lowest: compound 3; then compounds 2, 4 and 1 (each within the scatter of the next, the first and the last beyond it).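

In this assay, the step of a 27-fold higher number from compound 3 to compound 4 (1.43 log units; beyond the scatter) shows that, among the groups shown on an aromatic carbon para to a large group, the low number belongs to isopropyl alone. Methoxy gives no gain over hydrogen, with a 1.2-fold lower number from compound 1 to compound 4 (0.07 log units; within the scatter) as the step, and it also stands level with nitro, with a 1.8-fold higher number from compound 2 to compound 4 (0.26 log units; within the scatter) as the step. The compounds shown leave open whether an ethyl group, a tert-butyl group or an amine at this place would keep the low number of compound 3. Nothing presented here accounts for the difference between isopropyl and methoxy.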